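The source may report more compounds than this note shows. Statements on the series, on what has been measured and on what is new or still open speak of the compounds shown alone.

Measured in a physicochemical assay for solubility, in phosphate buffer, measured as kinetic solubility, with a stated time of 1 h, at pH 7.4; on this read-out higher numbers stand for higher solubility and lower numbers for lower solubility:
compound 1 `CCNC(=O)Nc1ccc(-c2nc(CS(C)(=O)=O)cc([C@]34CCOC[C@H]3C4)n2)cc1`: 96 ug/mL
compound 2 `CCNC(=O)Nc1ccc(-c2nccc([C@]34CCOC[C@H]3C4)n2)cc1`: 125 ug/mL
compound 3 `CCNC(=O)Nc1ccc(-c2nc(C(C)(C)S(C)(=O)=O)cc([C@]34CCOC[C@H]3C4)n2)cc1`: 74 ug/mL

Compound 2 cannot be set apart from the other two measured compounds. The steps that reach it are a 1.3-fold higher number from compound 1 to compound 2 (0.11 log units; within the scatter) and a 1.7-fold lower number from compound 2 to compound 3 (0.23 log units; within the scatter), and the remaining step is a 1.3-fold lower number from compound 1 to compound 3 (0.11 log units; within the scatter).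

Compound 4 `CCNC(=O)Nc1ccc(-c2nccc(C34CCOCC3C4)n2)cc1` differs from compound 2 only in how its stereochemistry is drawn: the two compounds have the same atoms and bonds; at least one stereo element is drawn with a configuration in one of them and without one in the other: 2 of 2 stereo elements differ; a stereocentre at a saturated ring carbon is drawn R in compound 2 and without a configuration in compound 4; a stereocentre at a saturated ring carbon is drawn S in compound 2 and without a configuration in compound 4.

Going by the values given here, none of the measured steps touches a stereocentre. Each exchanges a group on an aromatic carbon, so they bear on this change only indirectly, and even those exchanges stayed within the scatter in this assay. Among the compounds with values here, with no measured step of this kind, the expectation rests on compound 2 at 125 ug/mL. The expected step is a 1.0-fold lower number from compound 2 to compound 4 (0.02 log units; within the scatter), nothing beyond the scatter. Compound 4 is expected at 120 ug/mL, with an estimated range from 70 ug/mL to 200 ug/mL.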

Compound 4, solubility: 111 ug/mL
Compound 4: the middle estimate sits 1.1-fold (0.03 log units) above what was measured, within the range that was stated.
By their numbers in this assay, from the lowest: compounds 3, 1, 4 and 2 (each within the scatter of the next).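

Going by these compounds alone, the change in how the two stereocentres are drawn gives, in this assay, a 1.1-fold lower number from compound 2 to compound 4 (0.05 log units; within the scatter), and this is the first measured step to bear on these stereocentres directly rather than on a group on an aromatic carbon. The step gives no ground for setting compound 4 apart from compound 2 on this read-out, even though both stereo elements differ in how they are drawn. Only one thing separates this pair: the fact that one of compounds 2 and 4 is drawn with a defined configuration and the other without, at the place where they differ

On these data alone, how a compound drawn with both stereocentres in the opposite configuration would read remains open, since a drawing without configuration does not say what compound 4 contains. Also open, as far as these compounds go, is how an amine or a carboxylic acid would read in place of the (methylsulfonyl)methyl group on the aromatic carbon.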